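Bromo on the benzyl ring of a weak MMP-9 ester

This account rests on a few compounds, and the source may have more. Where it says the series, first, only, none or still open, it means among the compounds named here.

Measured so far:
compound 1 `O=C(Oc1cccc2ccccc12)c1cccc(S)n1`, > 150000 nM in an assay on isolated protein for inhibition of matrix metalloproteinase-9 (Homo sapiens); a lower number here means a stronger inhibitor, a higher number a weaker inhibitor
compound 2 `O=C(OCc1ccccc1)c1cccc(=O)[nH]1`, 69000 nM in this assay

In this assay compound 1 gives only a limit, > 150000 nM, and not a number. Compound 2 gives the only number shown, 69000 nM. Compound 3 `O=C(OCc1ccccc1Br)c1cccc(=O)[nH]1` differs from compound 2 by bromo in place of hydrogen on an aromatic carbon, ortho to a large group. Among the measured compounds shown here, no measured step of this kind is available, so the step of a 1.4-fold lower number from compound 2 to compound 3 (0.14 log units; within the scatter) is expected to stay within the scatter. Compound 3 is therefore expected to give 50000 nM, between 15000 nM and 150000 nM.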

Compound 3, half-maximal inhibitory concentration: 59000 nM
Beside the measured number, compound 3's estimate is 1.2-fold (0.07 log units) below it; measured number inside the range.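

Bromo in place of hydrogen on an aromatic carbon, ortho to a large group, gives a 1.2-fold lower number from compound 2 to compound 3 (0.07 log units; within the scatter) in this assay. Among the compounds shown here, this is the first measured step at this position, and it shows that one bromine atom placed there leaves no readable difference between the two esters. Compound 1 gives only a limit and not a number, so it says nothing about this position: the limit of > 150000 nM in this assay, at which 1 of the 3 values shown sits.

Going by these compounds, whether an amine or a carboxylic acid at this same position would move the number beyond the scatter stays open. So does the effect of bromo on another carbon of that ring.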